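The source may report more compounds than this note shows. Statements on the series, on what has been measured and on what is new or still open speak of the compounds shown alone.

Measured in an in vitro ADME assay on microsomes from liver (Mus musculus) for pharmacokinetics, read by LC-MS, with a stated time of 10 min, tested at 1 uM; on this read-out higher numbers stand for fast clearance and lower numbers for slow clearance:
Compound 1 `CN1C[C@H](C(=O)Nc2cccc(Cl)c2)[C@@H](c2ccc(/C=C/C(=O)Nc3ccccc3N)cc2)C1`: 58 mL/min/kg
Compound 2 `COc1cccc(NC(=O)[C@H]2CN(C)C[C@@H]2c2ccc(/C=C/C(=O)Nc3ccccc3N)cc2)c1`: 65 mL/min/kg
Compound 3 `CC(C)NC(=O)[C@H]1CN(C)C[C@@H]1c1ccc(/C=C/C(=O)Nc2ccccc2N)cc1`: 12 mL/min/kg

Compound 3 has the lowest number of the three. Compound 4 `CN1C[C@H](C(=O)NC2CC2)[C@@H](c2ccc(/C=C/C(=O)Nc3ccccc3N)cc2)C1` differs from it in one place, with cyclopropyl in place of isopropyl on an amide-type nitrogen. For the measured compounds named here, no measured step makes this exchange. The closest evidence comes from the same nitrogen, in a 4.8-fold lower number from compound 1 to compound 3 (0.68 log units; beyond the scatter) and a 5.4-fold lower number from compound 2 to compound 3 (0.73 log units; beyond the scatter). Both steps lie beyond the scatter, but each replaces an aromatic group, 3-chlorophenyl or 3-methoxyphenyl, so neither sizes a swap of isopropyl for cyclopropyl. No change beyond the scatter is therefore expected in this assay. The estimated step is a 1.1-fold higher number from compound 3 to compound 4 (0.03 log units; within the scatter). For compound 4 the expected clearance is 13 mL/min/kg, with an estimated range of 6 mL/min/kg to 28 mL/min/kg.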

Compound 4, clearance: 7 mL/min/kg
Compound 4: the middle estimate sits 1.9-fold (0.27 log units) above what was measured, within the range that was stated.
By their numbers in this assay, from the lowest: compounds 4 and 3 (each within the scatter of the next); then compounds 1 and 2 (each within the scatter of the next).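

In this assay, cyclopropyl in place of isopropyl on the amide-type nitrogen gives a 1.7-fold lower number from compound 3 to compound 4 (0.23 log units; within the scatter), so this exchange of a ring for an open group stays within the scatter. Cyclopropyl also parts clearly from the aromatic groups, with a 9.3-fold lower number from compound 2 to compound 4 (0.97 log units; beyond the scatter) and an 8.3-fold lower number from compound 1 to compound 4 (0.92 log units; beyond the scatter), so compound 3 is no longer the only compound with a non-aromatic group and a number well under those of the aryl amides. Nothing measured here explains these differences. Going by these compounds, it remains open whether a longer chain such as n-butyl, or a chain carrying an amine, on this nitrogen would stay with compound 3 and compound 4 or join compound 1 and compound 2.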